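The source may report more compounds than this note shows. Statements on the series, on what has been measured and on what is new or still open speak of the compounds shown alone.

In a functional assay (muscle tissue) with Cavia porcellus as the target (a lower number here means that less compound is needed, a higher number that more compound is needed for the effect), compound 1 `COC(=O)C1=C(C)N=C(C)/C(=C(\O)OC)C1c1cccc(N)c1` gives 2000 nM and compound 2 `COC(=O)C1=C(C)N=C(C)/C(=C(\O)OC)C1c1ccc(I)cc1` gives 22900 nM while compound 3 `COC(=O)C1=C(C)N=C(C)/C(=C(\O)OC)C1c1ccccc1Br` gives 7.59 nM and so has the lowest number of the three. The steps of a 260-fold lower number from compound 1 to compound 3 (2.42 log units; beyond the scatter) and a 3000-fold lower number from compound 2 to compound 3 (3.48 log units; beyond the scatter) are both large and beyond the scatter, as is an 11-fold higher number from compound 1 to compound 2 (1.06 log units; beyond the scatter) between the other two.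

Compound 4 `C=Cc1ccccc1C1C(C(=O)OC)=C(C)N=C(C)/C1=C(\O)OC` differs from compound 3 at one place: vinyl in place of bromo on an aromatic carbon with vinyl in place of bromo on an aromatic carbon, ortho to a large group. Among the compounds with values here, no measured step exchanges these two groups. Each of the three measured steps swaps one substituted phenyl for another, with group and place changing together, so they show the span of this assay across the series but do not isolate this change. Compound 4 keeps a group at the place held by bromo in compound 3, so a step on the scale of a 3000-fold lower number from compound 2 to compound 3 (3.48 log units; beyond the scatter) is not expected. Within the data shown here, with compound 3 at 7.59 nM as the lowest number so far, a moderate move toward a higher number seems more likely than a further fall. The estimated step is a 3.3-fold higher number from compound 3 to compound 4 (0.52 log units; beyond the scatter) and is expected to be modest next to the measured ones. For compound 4 the estimated value is 25 nM with an expected range from 4 nM to 150 nM at the upper end.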

Compound 4, half-maximal effective concentration: 4.47 nM
Compound 4: middle estimate off by 5.6-fold (0.75 log units), on the high side; low and high end bracket the measured number.
By their numbers in this assay, from the lowest: compounds 4 and 3 (each within the scatter of the next); then compound 1; then compound 2.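

In this assay, the exchange of bromo for vinyl on an aromatic carbon, ortho to a large group, gives a 1.7-fold lower number from compound 3 to compound 4 (0.23 log units; within the scatter), so this place accepts either group, one of a single heavy atom and one of two carbons with a double bond, without a change that can be read. The 2-vinylphenyl group keeps the wide separation from the other two aryl groups, with a 5100-fold lower number from compound 2 to compound 4 (3.71 log units; beyond the scatter) and a 450-fold lower number from compound 1 to compound 4 (2.65 log units; beyond the scatter), so among these four compounds that separation is not tied to bromo alone. No measurement bears on why bromo and vinyl give numbers within the scatter of each other.

From the compounds shown here alone, whether this tolerance extends to a longer chain such as propyl, or to an amine or a carboxylic acid at the same place, stays open. Going by these compounds, compound 1 and compound 2 differ from compound 3 and compound 4 in group and place together, so the share of the large steps that belongs to the place alone also stays open.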